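Aryl ketone variation on the shared core

The compounds below may be only part of what the source reports. "The series", "measured", "known", "first", "only" and "open" are said of these compounds alone.

Compound 1 `COc1cc(-c2cc(/C=C/C(=O)c3ccc(N)cc3)[nH]n2)cc(OC)c1OC` gives 1740 nM in a functional assay on COLO 205 cells (Homo sapiens) for inhibition, read by sulforhodamine B assay, with a stated time of 48 h; on this read-out lower numbers stand for stronger inhibition of growth and higher numbers for weaker inhibition of growth. Compound 2 `COc1ccc(-c2cc(/C=C/C(=O)c3ccc(OC)c(OC)c3)[nH]n2)cc1` gives 1760 nM in this assay; the two values lie within the scatter of one another, so compound 1 stands lowest of the two in number only, not in any real sense. Compound 3 `COc1cc(-c2cc(/C=C/C(=O)c3ccc(Cl)c(Cl)c3)[nH]n2)cc(OC)c1OC` differs from compound 1 by 3,4-dichlorophenyl in place of 4-aminophenyl on a carbonyl carbon. For the measured compounds named here, no measured pair shows this change, so no step size is established. Without such a step, only a modest shift is expected, with a 1.2-fold lower number from compound 1 to compound 3 (0.09 log units; within the scatter) likely staying near or within the scatter. Compound 3 is therefore expected to give about 1400 nM, within a range from 350 nM to 5600 nM.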

Compound 3, concentration for 50% growth inhibition: 1260 nM
Estimate against measurement, compound 3: 1.1-fold (0.05 log units) above; low and high end bracket the measured number.
By their numbers in this assay, from the lowest: compounds 3, 1 and 2 (each within the scatter of the next).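

In this assay, for the compounds shown here, the first step at this position, 3,4-dichlorophenyl in place of 4-aminophenyl on a carbonyl carbon, gives a 1.4-fold lower number from compound 1 to compound 3 (0.14 log units; within the scatter) and so does not separate the two groups. The hydrogen-bond donor and acceptor counted on 4-aminophenyl are absent from 3,4-dichlorophenyl, yet the two compounds cannot be told apart on this read-out. No measurement at hand explains this result. Open is whether a carboxylic acid or a morpholine on the phenyl ring at this position would give a number beyond the scatter of these compounds.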